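This account rests on a few compounds, and the source may have more. Where it says the series, first, only, none or still open, it means among the compounds named here.

In a functional assay on Ehrlich cells (Mus musculus) for antiproliferative activity, read by trypan blue exclusion, with a stated time of 2 h (on this read-out lower numbers stand for stronger inhibition and higher numbers for weaker inhibition), compound 3 `COc1ccc(C2C(C#N)=C(N)N(c3ccc(S(N)(=O)=O)cc3)C3=C2C(=O)CCC3)cc1` gives 25 ug/mL, the highest of the two numbers shown. Compound 1 `N#CC1=C(N)N(c2ccc(S(N)(=O)=O)cc2)C2=C(C(=O)CCC2)C1c1ccc(O)cc1` gives 3 ug/mL. For compound 2 `N#CC1=C(N)N(c2ccc(S(N)(=O)=O)cc2)C2=C(C(=O)CCC2)C1/C=C/c1ccccc1` the assay reports only a limit, > 100 ug/mL. Compound 4 `N#CC1=C(N)N(c2ccc(S(N)(=O)=O)cc2)C2=C(C(=O)CCC2)C1c1ccc([N+](=O)[O-])cc1` differs from compound 3 by nitro in place of methoxy on an aromatic carbon. The measured step nearest this change is an 8.3-fold higher number from compound 1 to compound 3 (0.92 log units; beyond the scatter), where the group on the aromatic ring also varied; the other step, an at least 4.0-fold lower number from compound 2 to compound 3 (0.60 log units; beyond the scatter), concerns a larger exchange of the whole substituent. Within the data shown here, no measured pair contains a nitro group, so the direction of the new step is uncertain, and only a modest step in this assay is expected. Compound 4 is therefore estimated at 15 ug/mL, with a range from 4 ug/mL to 60 ug/mL, which means a 1.7-fold lower number from compound 3 to compound 4 (0.22 log units; within the scatter).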

Compound 4, half-maximal inhibitory concentration: 2.5 ug/mL
The estimate for compound 4 lay 6.0-fold (0.78 log units) above the measured number; measured number below the stated range.
By their numbers in this assay, from the lowest: compounds 4 and 1 (each within the scatter of the next); then compound 3. At a limit, above all of these: compound 2.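

Among these compounds, at this aromatic carbon, para to a large group, the change from methoxy to nitro gives a 10-fold lower number from compound 3 to compound 4 (1.00 log units; beyond the scatter) in this assay, so a free hydroxy is not the only group that gives a low number here. Nitro and hydroxy cannot be told apart on this read-out, with a 1.2-fold lower number from compound 1 to compound 4 (0.08 log units; within the scatter), which leaves compound 3 as the one aryl compound apart. The exchange for 2-phenylethenyl gives an at least 40-fold lower number from compound 2 to compound 4 (1.60 log units; beyond the scatter), a step that rests on a limit: the limit of > 100 ug/mL in this assay, at which 1 of the 4 values shown sits.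

On these data alone, whether an amine, a carboxylic acid or a plain hydrogen at this carbon would fall with compound 1 and compound 4 or with compound 3 stays open.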